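A few compounds are considered here, and "the series" means these few. Any claim that something is new, unique, unknown or untested is made for them only; others in the source may bear on it.

Measured so far:
Compound 1, `CC(C(=O)NCc1ccc(C(F)(F)F)cc1N1CCC(c2ccc(F)cc2)CC1)c1ccc(NS(C)(=O)=O)c(F)c1`, gives 0.9 nM in an assay on CHO cells for antagonist activity at transient receptor potential cation channel subfamily V member 1 (Homo sapiens), read by FLIPR; a lower number here means a stronger inhibitor, a higher number a weaker inhibitor.
Compound 2, `CCCCCCOc1cc(C(C)(F)F)ccc1CNC(=O)C(C)c1ccc(NS(C)(=O)=O)c(F)c1`, gives 0.8 nM in this assay.
Compound 3, `CC(C)CCSc1cc(C(F)(F)F)ccc1CNC(=O)C(C)c1ccc(NS(C)(=O)=O)c(F)c1`, gives 1.4 nM in this assay.

Compound 3 has the highest of the three numbers, yet its gaps to compound 1 and to compound 2 both lie within the scatter, so the three compounds stand together and no order among them can be read.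

Compound 4, `COc1cc(OC)cc(-c2cc(C(F)(F)F)ccc2CNC(=O)C(C)c2ccc(NS(C)(=O)=O)c(F)c2)c1`, is not yet measured. It differs from compound 3 as follows: 3,5-dimethoxyphenyl in place of isopentylsulfanyl on an aromatic carbon. Going by the values given here, no step between two measured compounds is available for comparison. The measured compounds differ from one another in the same part of the shared core and still all stand together, which argues for tolerance there; the entering group is, however, a ring in place of a chain, so a modest move toward a higher number, possibly not beyond the scatter, is expected in this assay. Compound 4 is therefore estimated at 3 nM, with a range of 0.8 nM to 12 nM. The expected step is a 2.1-fold higher number from compound 3 to compound 4 (0.33 log units; beyond the scatter).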

Compound 4, inhibition constant: 5.8 nM
For compound 4 the middle estimate is 1.9-fold (0.29 log units) below the measured one; low and high end bracket the measured number.
By their numbers in this assay, from the lowest: compounds 2, 1 and 3 (each within the scatter of the next); then compound 4.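

Going by these compounds alone, at this aromatic carbon, ortho to a large group and meta to a trifluoromethyl group, 3,5-dimethoxyphenyl in place of isopentylsulfanyl gives a 4.1-fold higher number from compound 3 to compound 4 (0.62 log units; beyond the scatter) in this assay and is the only step that lies beyond the scatter. The position is therefore not indifferent to the group it carries, though the step is modest and compound 4 still gives 5.8 nM with a ring at this carbon. No measurement shown accounts for the step.

From the compounds shown here alone, whether the step follows the ring itself or its two methoxy groups stays open, and a plain phenyl would separate the two. Also open, going by these compounds, is how a saturated ring such as cyclohexyl, or a chain ending in a carboxylic acid, would fare at this carbon.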